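Removing one chloro: expected cytotoxicity of compound 4

This account rests on a few compounds, and the source may have more. Where it says the series, first, only, none or still open, it means among the compounds named here.

Compound 1 `O=S1(=O)N=C(OCc2ccccc2)c2ccccc2N1Cc1ccccc1` gives 200000 nM in a functional assay on HEL cells (Homo sapiens); on this read-out lower numbers stand for higher toxicity in this test and higher numbers for lower toxicity in this test. Compound 2 `O=C1c2ccccc2N(Cc2ccc(Cl)cc2)S(=O)(=O)N1Cc1ccccc1` shows only a limit of this assay, > 5000 nM. Compound 3 `O=C1c2ccccc2N(Cc2ccccc2Cl)S(=O)(=O)N1Cc1ccccc1Cl` likewise returns only a limit, > 20000 nM, so it stands at the limit of > 20000 nM in this assay, at which 1 of the 3 values shown sits, and no number is fixed for it. Compound 4 `O=C1c2ccccc2N(Cc2ccccc2Cl)S(=O)(=O)N1Cc1ccccc1` differs from compound 3 by hydrogen in place of chloro on an aromatic carbon. For the measured compounds named here, no step between two measured compounds is available to gauge this change, and compound 2 with its limit still carries chloro on one ring. All three values sit at weak toxicity. For compound 4 no more than a small step is expected, within the scatter, a step that the limit leaves unreadable from compound 3 to compound 4. Compound 4 is estimated at 50000 nM in this assay, between 10000 nM and 200000 nM.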

Compound 4, minimum cytotoxic concentration: 200000 nM
Compound 4: the middle estimate sits 4.0-fold (0.60 log units) below what was measured; the range from low to high includes it.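

Neither the step to compound 4 from compound 3 nor that from compound 2 can be read, as both starting values are only limits. The compounds shown leave open whether hydrogen in place of chloro on an aromatic carbon changes toxicity at all.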